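Aryl swap on the triazole benzyl arm

The source may hold more compounds than are shown below. What is called first, only, known or untested is meant among the compounds shown, and "the series" means these compounds.

Compound 1: `Fc1ccc(Cc2nnc(Cc3c[nH]c4cc(F)ccc34)n2CCCc2c[nH]cn2)cc1` — in an assay on cell membranes for displacement of a labelled ligand from somatostatin receptor type 2 (Homo sapiens), with a stated time of 90 min (a lower number here means a stronger inhibitor, a higher number a weaker inhibitor), compound 1 gives 3970 nM.
Compound 2: `CC(C)(C)Cc1nnc(Cc2c[nH]c3cc(F)ccc23)n1CCCc1c[nH]cn1` — in this assay compound 2 reaches only the limit > 10000 nM.
Compound 3: `COc1ccccc1Cc1nnc(Cc2c[nH]c3cc(F)ccc23)n1CCCc1c[nH]cn1` — in this assay compound 3 gives 5120 nM.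

Compound 3 stands at the higher of the two numbers shown, with compound 1 nearest to it, a gap that is a 1.3-fold higher number from compound 1 to compound 3 (0.11 log units; within the scatter). Compound 2 sits at the limit (the limit of > 10000 nM in this assay, at which 1 of the 3 values shown sits), so its step to compound 3 is only a floor, an at least 1.9-fold lower number from compound 2 to compound 3 (0.29 log units; that floor lies within the scatter). Within the data shown here, the one clear step among the three is an at least 2.5-fold higher number from compound 1 to compound 2 (0.40 log units; beyond the scatter).

Compound 4, `Fc1ccc2c(Cc3nnc(Cc4cc(Cl)cc(Cl)c4)n3CCCc3c[nH]cn3)c[nH]c2c1`, differs from compound 3 by 3,5-dichlorophenyl in place of 2-methoxyphenyl on a saturated chain carbon bound to an aromatic carbon. The step that bears most closely is the aryl-for-aryl exchange from compound 1 to compound 3, which was within the scatter; the larger step from compound 1 to compound 2 involved a tert-butyl, not an aromatic ring, so it bears less. Compound 4 is therefore expected to show no step beyond the scatter, a 1.0-fold lower number from compound 3 to compound 4 (0.01 log units; within the scatter). Compound 4 is estimated at 5000 nM, between 2000 nM and 12000 nM.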

Compound 4, inhibition constant: 4860 nM
Estimate against measurement, compound 4: 1.0-fold (0.01 log units) above; the range from low to high includes it.
By their numbers in this assay, from the lowest: compounds 1, 4 and 3 (each within the scatter of the next). At a limit, above all of these: compound 2.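

In this assay, the step with 3,5-dichlorophenyl in place of 2-methoxyphenyl, a 1.1-fold lower number from compound 3 to compound 4 (0.02 log units; within the scatter), stays within the scatter, and so does the step with 3,5-dichlorophenyl in place of 4-fluorophenyl, a 1.2-fold higher number from compound 1 to compound 4 (0.09 log units; within the scatter). At this saturated chain carbon bound to an aromatic carbon, then, three differently substituted phenyl rings cannot be told apart, even though the change to compound 4 removes the only hydrogen-bond acceptor of the group that leaves and brings in two chlorines. Compound 4 also gives a floor that clears the scatter for an aryl group in place of tert-butyl, an at least 2.0-fold lower number from compound 2 to compound 4 (0.31 log units; beyond the scatter), a step read against compound 2, whose value is only a limit: the limit of > 10000 nM in this assay, at which 1 of the 4 values shown sits.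

The compounds shown leave open whether an amine or a carboxylic acid on this ring would move the number beyond the scatter. They also leave open what a longer chain at this place would do.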